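The source may hold more compounds than are shown below. What is called first, only, known or untested is meant among the compounds shown, and "the series" means these compounds.

In a functional assay on MDA-MB-231 cells (Homo sapiens) for cytotoxicity, read by MTT assay, with a stated time of 72 h (a higher number here means a weaker inhibitor, a lower number a stronger inhibitor), compound 1 (`Nc1ccccc1NC(=O)c1ccc(NC(=S)NCc2ccccc2F)cc1`) gives > 100000 nM, which is a limit of the assay and not a number. Compound 2 (`Nc1ccccc1NC(=O)c1ccc(NC(=O)NCc2cccnc2)cc1`) gives > 100000 nM, again a limit. Compound 3 (`Nc1ccccc1NC(=O)c1ccc(NC(=O)NCc2ccc(F)nc2)cc1`) gives a true number, 91000 nM. What stands out in this small set is the limit of > 100000 nM in this assay, at which 2 of the 3 values shown sit.

The next compound to be tested is compound 4 (`Cc1ccc(CNC(=S)Nc2ccc(C(=O)Nc3ccccc3N)cc2)cn1`), which differs from compound 1 as follows: 6-methylpyridin-3-yl in place of 2-fluorophenyl on a saturated chain carbon bound to an amide-type nitrogen. Among the compounds with values here, no measured step makes this exchange. The closest evidence comes from compound 2 and compound 3, which also carry an aromatic ring with a hetero atom, though with a carbonyl where compound 1 has a thiocarbonyl. Within the data shown here, the one measured step between them is an at least 1.0-fold lower number from compound 2 to compound 3 (0.04 log units; that floor lies within the scatter), and it does not go beyond the scatter. Neither of these two compounds shows strong activity in this assay, so nothing measured points to a gain from the entering 6-methylpyridin-3-yl.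

The expected change is an at least 1.0-fold lower number from compound 1 to compound 4 (0.02 log units; that floor lies within the scatter), with no shift beyond the scatter anticipated. Compound 4 is estimated at 95000 nM, with an expected range from 45000 nM to 200000 nM. It may well be reported only as a limit.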

Compound 4, half-maximal inhibitory concentration: 63000 nM
Beside the measured number, compound 4's estimate is 1.5-fold (0.18 log units) above it, within the range that was stated.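

In this assay, the exchange of 2-fluorophenyl for 6-methylpyridin-3-yl on a saturated chain carbon bound to an amide-type nitrogen brings the thiocarbonyl series off the limit and onto a true number, something compound 1 alone could not show for this position. The change reads as an at least 1.5-fold lower number from compound 1 to compound 4 (0.20 log units; that floor lies within the scatter), and this is only a floor, because compound 1 stands at a limit of the assay and not at a number: the limit of > 100000 nM in this assay, at which 2 of the 4 values shown sit. The printed floor gives no gain beyond the scatter, so the result shows that this position accepts a ring with a hetero atom in place of the 2-fluorophenyl, but not that the exchange brings a real gain.

The compounds shown leave open how large the true gap from compound 1 is, and whether the ring nitrogen or the methyl of the entering group accounts for the number. They also leave open what a methoxy group or a primary amine in place of that methyl would give at this place.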